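This account rests on a few compounds, and the source may have more. Where it says the series, first, only, none or still open, it means among the compounds named here.

In a functional assay on A2780 cells (Homo sapiens) for inhibition, read by sulforhodamine B assay, with a stated time of 3 days (a higher number here means a weaker inhibitor, a lower number a stronger inhibitor), the measured compounds read as follows:

compound 1 `O=C1Nc2ccccc2/C1=C\C(=O)c1c[nH]c2ccccc12` gives 2080 nM
compound 2 `O=C1Nc2ccc(F)cc2/C1=C\C(=O)c1cnc2ccc(Cl)nn12` gives 2370 nM
compound 3 `CN1CCN(c2cccc(N/C=C3\C(=O)Nc4ccc(NC(=O)c5cccc(F)c5)cc43)c2)CC1` gives 2910 nM

These three values lie within the usual scatter of one another, so the numbers set no order among them, although the structures are far from alike. Compound 3, at 2910 nM in this assay, therefore stands level with both compound 1 and compound 2.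

Compound 4 `CN1CCN(c2cccc(N/C=C3\C(=O)Nc4ccc(NC(=O)c5c(Cl)cccc5Cl)cc43)c2)CC1` has not yet been measured. It differs from compound 3 in one place, on a carbonyl carbon whose other neighbour is an amide-type nitrogen, where 2,6-dichlorophenyl stands in place of 3-fluorophenyl (2,6-dichlorophenyl in place of 3-fluorophenyl on a carbonyl carbon). Within the data shown here, no two measured compounds differ in only one place, so the data offer no step from which to size this change. The expectation rests instead on compound 3 at 2910 nM and the close grouping of the three values, and on that basis no step beyond the scatter is expected in either direction. The estimated step is a 1.2-fold lower number from compound 3 to compound 4 (0.07 log units; within the scatter) and it is expected to stay within the scatter. Compound 4 is expected at 2500 nM (estimated range 800 nM to 8000 nM).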

Compound 4, half-maximal inhibitory concentration: 2140 nM
Estimate against measurement, compound 4: 1.2-fold (0.07 log units) above; measured number inside the range.
By their numbers in this assay, from the lowest: compounds 1, 4, 2 and 3 (each within the scatter of the next).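

Among these compounds, this pair gives the first step in the set that can be read at a single place. In this assay, putting 2,6-dichlorophenyl in place of 3-fluorophenyl on a carbonyl carbon whose other neighbour is an amide-type nitrogen gives a 1.4-fold lower number from compound 3 to compound 4 (0.13 log units; within the scatter). At this position, then, a ring carrying two chlorine atoms and a ring carrying one fluorine atom cannot be told apart by this read-out, and no evidence at hand bears on the result.

That conclusion rests on one pair and two substituted phenyl groups, so it cannot be extended to the position as a whole. Going by these compounds, it remains open whether an unsubstituted phenyl, a small alkyl such as methyl, a longer chain ending in an amine or a carboxylic acid on the same carbonyl carbon would also stay within the scatter of compound 3, or would move the number clearly in either direction.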